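The source may hold more compounds than are shown below. What is called first, only, known or untested is meant among the compounds shown, and "the series" means these compounds.

Measured in a functional assay on Jurkat cells (Homo sapiens) for inhibition, read by MTT assay, with a stated time of 72 h; a higher number here means a weaker inhibitor, a lower number a stronger inhibitor:
- compound 1 `C=C(Br)C(=O)Nc1cccc(/C=C/C(=O)Nc2ccccc2)c1`: 5000 nM
- compound 2 `C=C(Br)C(=O)Nc1cccc(/C=C/C(=O)Nc2ccc(F)cc2)c1`: 6200 nM
- compound 3 `C=C(Br)C(=O)Nc1cccc(/C=C/C(=O)Nc2ccc(F)c(F)c2)c1`: 550 nM

Of these three, compound 3 has the lowest number, which makes it the strongest inhibitor so far. The next compound to be tested is compound 4 `C=C(Br)C(=O)Nc1cccc(/C=C/C(=O)Nc2ccc(C)cc2)c1`, which carries 4-methylphenyl in place of 3,4-difluorophenyl on an amide-type nitrogen.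

For the measured compounds named here, three measured steps bear on this change. Removing 3,4-difluorophenyl has been costly: the reverse of the change to it appears in a 9.1-fold lower number from compound 1 to compound 3 (0.96 log units; beyond the scatter) and in the larger 11-fold lower number from compound 2 to compound 3 (1.05 log units; beyond the scatter). By contrast, a 1.2-fold higher number from compound 1 to compound 2 (0.09 log units; within the scatter) lies within the scatter. Going by the values given here, the low number has so far appeared only with 3,4-difluorophenyl, and no measured compound carries a methyl group, so the size of the step remains uncertain.

A clear move toward a higher number is therefore expected, with the expected step being a 4.5-fold higher number from compound 3 to compound 4 (0.66 log units; beyond the scatter). The estimated value for compound 4 is 2500 nM, with an expected range from 700 nM to 8000 nM.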

Compound 4, half-maximal inhibitory concentration: 240 nM
The estimate for compound 4 lay 10-fold (1.02 log units) above the measured number; the measured number lies below the stated range.
By their numbers in this assay, from the lowest: compound 4; then compound 3; then compounds 1 and 2 (each within the scatter of the next).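

In this assay, a low number does not depend on 3,4-difluorophenyl on the amide-type nitrogen, since 4-methylphenyl in its place gives a 2.3-fold lower number from compound 3 to compound 4 (0.36 log units; beyond the scatter) and so goes further. A single small group on the aromatic carbon can therefore matter greatly: exchanging fluoro for methyl gives a 26-fold lower number from compound 2 to compound 4 (1.41 log units; beyond the scatter) and adding methyl in place of hydrogen gives a 21-fold lower number from compound 1 to compound 4 (1.32 log units; beyond the scatter), whereas compounds 1 and 2 stand within the scatter of each other. Nothing shown here explains why methyl and fluoro differ so much.

On these data alone, whether the gain is particular to methyl or continues with a longer chain such as ethyl in its place remains open. As far as these compounds go, it is also open whether an amine or a methoxy group there would keep the number this low.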